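Fluoro Where Bromo Once Stood: Expected Effect on Potency

The source may report more compounds than this note shows. Statements on the series, on what has been measured and on what is new or still open speak of the compounds shown alone.

Compound 1 `Cc1cc(C(=O)O)nn1Cc1cc(Br)ccc1OCc1ccc(Cl)cc1Cl`: 0.49 nM
Compound 2 `Cc1cc(C(=O)O)nn1Cc1ccccc1OCc1ccc(Cl)cc1Cl`: 8.32 nM

Within the data shown here, in a functional assay on CHO-K1 cells for antagonist activity at prostaglandin E2 receptor EP1 subtype (Homo sapiens), read by FLIPR (a lower number here means a stronger inhibitor, a higher number a weaker inhibitor), compound 2 gives 8.32 nM, the highest of the two numbers measured; its only neighbour, compound 1, gives 0.49 nM. Among the measured compounds shown here, the single measured step, a 17-fold higher number from compound 1 to compound 2 (1.23 log units; beyond the scatter), is a large one and tells how much the bromo at that aromatic carbon mattered.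

Compound 3 `Cc1cc(C(=O)O)nn1Cc1cc(F)ccc1OCc1ccc(Cl)cc1Cl` differs from compound 2 by fluoro in place of hydrogen on an aromatic carbon. The fluoro enters at the same carbon the bromo occupied in compound 1, so the measured step bears directly on it, though with a different halogen. The account therefore expects a step in the lower direction in this assay, beyond the scatter but smaller than the step from compound 1 to compound 2, since no data show a fluoro matching bromo. For compound 3 the estimate is 3 nM, in the range 1 nM to 8 nM, a step of a 2.8-fold lower number from compound 2 to compound 3 (0.44 log units; beyond the scatter).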

Compound 3, inhibition constant: 20.4 nM
The estimate for compound 3 lay 6.8-fold (0.83 log units) below the measured number, outside the stated range (above it).
By their numbers in this assay, from the lowest: compound 1; then compound 2; then compound 3.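

Fluoro and bromo at this aromatic carbon do not act alike in this assay: fluoro in place of hydrogen gives a 2.5-fold higher number from compound 2 to compound 3 (0.39 log units; beyond the scatter) and so moves the number the opposite way from bromo, which stands far lower. Fluoro in place of bromo gives a 42-fold higher number from compound 1 to compound 3 (1.62 log units; beyond the scatter), a larger step than the one to hydrogen, a 17-fold higher number from compound 1 to compound 2 (1.23 log units; beyond the scatter), so the potency of compound 1 belongs to the bromo itself and not to any halogen at this carbon. Nothing measured here bears on the cause of this split between the two halogens.

The compounds shown leave open whether chloro, iodo or methyl at the same carbon would stand nearer to bromo or to fluoro. They also leave open whether the bromo gain would persist if an amide replaced the carboxylic acid.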